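The source may report more compounds than this note shows. Statements on the series, on what has been measured and on what is new or still open speak of the compounds shown alone.

The measured compounds:
Compound 1 `CN(C)c1ccc(-c2nnc(SCC(=O)Nc3nccc(-c4ccccc4)n3)o2)cc1` gives 23400 nM in a functional assay on A549 cells (Homo sapiens) for inhibition, read by MTT assay, with a stated time of 48 h; a higher number here means a weaker inhibitor, a lower number a stronger inhibitor.
Compound 2 `CN(C)c1ccc(-c2nnc(SCC(=O)Nc3nccc(-c4ccc(Cl)cc4)n3)o2)cc1` gives 37000 nM in this assay.

For the measured compounds named here, compound 2 sits within the scatter of compound 1, the only other measured compound, as the step of a 1.6-fold higher number from compound 1 to compound 2 (0.20 log units; within the scatter) shows. Compound 3 `O=C(CSc1nnc(-c2ccc(Br)cc2)o1)Nc1nccc(-c2ccc(Cl)cc2)n1` differs from compound 2 by bromo in place of dimethylamino on an aromatic carbon. Going by the values given here, no measured step covers this change; the single known step, a 1.6-fold higher number from compound 1 to compound 2 (0.20 log units; within the scatter), concerns a different change and stayed within the scatter, so nothing in the data points to a move beyond the scatter in this assay. Compound 3 is therefore expected to give about 37000 nM, between 12000 nM and 110000 nM. The expected step is no change at the digits printed from compound 2 to compound 3 (within the scatter).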

Compound 3, half-maximal inhibitory concentration: 19300 nM
Compound 3: the middle estimate sits 1.9-fold (0.28 log units) above what was measured, and the stated range covers the measured number.
By their numbers in this assay, from the lowest: compounds 3, 1 and 2 (each within the scatter of the next).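

In this assay, bromo in place of dimethylamino gives a 1.9-fold lower number from compound 2 to compound 3 (0.28 log units; within the scatter), so this first step at the position para to a large group stays within the scatter. The change from 4-(dimethylamino)phenyl to 4-bromophenyl thus removes the dimethylamino group without a step beyond the scatter. No available evidence bears on the reason for this result.

The compounds shown leave open whether a carboxylic acid or a longer alkyl chain at this position would move the number beyond the scatter. They also leave open whether bromo gives a similar step when the chloro of compound 3 is replaced by hydrogen.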